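The compounds below may be only part of what the source reports. "The series", "measured", "known", "first", "only" and "open" are said of these compounds alone.

Four compounds share a two-ring core that carries a sulfonyl-linked aryl group and a second aryl group side by side. Compound 1 `COc1ccc(S(=O)(=O)c2cnc3c(F)cccc3c2-c2cccc(Cl)c2)cc1` and compound 2 `COc1ccc(-c2c(S(=O)(=O)c3ccc(OC)cc3)cnc3c(F)cccc23)cc1` have the same core, while compound 3 `COc1ccc(-c2c(S(=O)(=O)c3ccc(C)c(C)c3)cnc3cc(F)ccc23)cc1` and compound 4 `Cc1ccc(S(=O)(=O)c2cnc3cc(F)ccc3c2-c2cccc(Cl)c2)cc1C` have a core whose difference from that of compound 2 is not broken down here.

In an ADME assay on microsomes from liver (Homo sapiens) for metabolic stability, tested at 2.5 uM (a lower number here means slower removal, a higher number faster removal of the compound), compound 2 gives 2.12 mL/min and compound 1 gives 2.75 mL/min. The change between them is 3-chlorophenyl in place of 4-methoxyphenyl on an aromatic carbon, and it produced a 1.3-fold higher number from compound 2 to compound 1 (0.11 log units; within the scatter). Compound 3 gives 4.13 mL/min in this assay; its value and those of compounds 1 and 2 all sit within the usual scatter of one another.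

Compound 4 is made from compound 3 by 3-chlorophenyl in place of 4-methoxyphenyl on an aromatic carbon, the same change at the same place. Because a 1.3-fold higher number from compound 2 to compound 1 (0.11 log units; within the scatter) was the outcome of that change, a similar step, a 1.3-fold higher number from compound 3 to compound 4 (0.12 log units; within the scatter), is expected here. On that basis compound 4 is expected to give about 5.4 mL/min in this assay, most likely between 3 mL/min and 9.5 mL/min.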

Compound 4, intrinsic clearance in a liver preparation (reported as CLH), per the amount of preparation that the assay uses: 4.01 mL/min
Beside the measured number, compound 4's estimate is 1.3-fold (0.13 log units) above it, and the stated range covers the measured number.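

Replacing 4-methoxyphenyl with 3-chlorophenyl gives a 1.0-fold lower number from compound 3 to compound 4 (0.01 log units; within the scatter) in this assay, so on this core the swap also leaves the read-out within the usual scatter. Set beside the earlier step, the two cores give the same picture: the same change on two cores in this assay, a 1.3-fold higher number (0.11 log units; within the scatter) from compound 2 to compound 1 and a 1.0-fold lower number (0.01 log units; within the scatter) from compound 3 to compound 4, 1.3-fold (0.13 log units) apart, within the scatter of two such steps. For these two pairs, the change carries from one core to the other without a detectable shift in the rate of removal, but this does not show that the change has no effect at all, as steps this small cannot be told apart from the scatter of repeated measurements, and two pairs cannot set a rule for the whole series.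

Still open, going by these compounds, is whether a more different group in this place, such as a phenyl ring carrying an amine or a carboxylic acid, would take the read-out beyond the scatter. Also open, on these data alone, is whether the same swap would stay this quiet on a core other than these two.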